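Branching the Ester Chain on a Thiophene-Bearing Core

This account rests on a few compounds, and the source may have more. Where it says the series, first, only, none or still open, it means among the compounds named here.

The three measured compounds and their values:
Compound 1, `CCCOC(=O)C1=C(C)NC(=O)NC1c1ccoc1`, gives 11% in an assay on membranes from HeLa cells for displacement of a labelled ligand from adenosine receptor A3 (Homo sapiens), read by scintillation counting, with a stated time of 180 min, tested at 1 uM; on this read-out higher numbers stand for more inhibition at the one concentration tested (going by the name of the read-out) and lower numbers for less inhibition.
Compound 2, `CC1=C(C(=O)OCC(C)C)C(c2ccoc2)NC(=O)N1`, gives 16% in this assay.
Compound 3, `CCCOC(=O)C1=C(C)N(C)C(=O)NC1c1ccsc1`, gives 11% in this assay.

Compound 2 arises from compound 1 by one change, (methyl in place of hydrogen on a saturated chain carbon bound to two saturated chain carbons), and this change produced a number 5 percentage points higher from compound 1 to compound 2 (within the scatter). A step of that size cannot be told apart from the run-to-run noise of the measurement, so on this evidence the branching of the ester chain left the read-out essentially where it was.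

Compound 3 belongs to a different core; the difference between the two cores is not broken down here. What can be said is that compound 3 and compound 1 sit level at the digits given, and both are together the lowest of the three numbers, with compound 2 a little higher but still within the scatter.

Compound 4, `CC1=C(C(=O)OCC(C)C)C(c2ccsc2)NC(=O)N1C`, is not yet measured. It arises from compound 3 by methyl in place of hydrogen on a saturated chain carbon bound to two saturated chain carbons, the same change as from compound 1 to compound 2. Because the earlier version of this change gave a number 5 percentage points higher from compound 1 to compound 2 (within the scatter), the expected step from compound 3 to compound 4 is a number 4 percentage points higher from compound 3 to compound 4 (within the scatter), again within the scatter. In this assay compound 4 is therefore estimated at 15%, with a likely range from 3% to 28%.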

Compound 4, a percentage reported as inhibition, at one concentration (the size of the read-out at that concentration, not a potency): 4%
For compound 4 the middle estimate is 11 percentage points above the measured one, within the range that was stated.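

Going by these compounds alone, the methyl that turns the propyl chain of compound 3 into the isobutyl chain of compound 4 gave a number 7 percentage points lower from compound 3 to compound 4 (within the scatter) in this assay, so on this second core the change again produced no step that can be told apart from the noise. Set side by side, the two steps point in opposite directions, yet they cannot be distinguished from each other: the same change on two cores in this assay, a number 5 percentage points higher (within the scatter) from compound 1 to compound 2 and a number 7 percentage points lower (within the scatter) from compound 3 to compound 4, 12 percentage points apart, within the scatter of two such steps This shows no measurable dependence on the core, but it does not show that the change carries over reliably, as neither step stands clear of the scatter and so there is no established effect to transfer, and two cores are a small sample in any case.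

The compounds shown leave open what a clearly different ester group would do, such as a longer chain like hexyl, an amine at the end of the chain, or a carboxylic acid in place of the ester. They also leave open whether any change in this series can move the inhibition beyond the scatter, and a percentage at a single concentration gives no potency for any of these compounds.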